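The source may report more compounds than this note shows. Statements on the series, on what has been measured and on what is new or still open speak of the compounds shown alone.

Three compounds have been measured in a functional assay on L1210 cells (Mus musculus); on this read-out lower numbers stand for stronger inhibition and higher numbers for weaker inhibition:
compound 1 `COc1ccc(/C=C/C(=O)Oc2ccc(/C=C3\CCCCC3=O)cc2)cc1` with 10200 nM;
compound 2 `O=C(/C=C/c1ccc(Br)cc1)Oc1ccc(/C=C2\CCCCC2=O)cc1` with 127000 nM;
compound 3 `CN(C)CC1CCC/C(=C\c2ccc(OC(=O)/C=C/c3ccc(Br)cc3)cc2)C1=O` with 1780 nM.

Compound 3 gives the lowest number of the three, clearly apart from compound 1 and furthest from compound 2. Two steps between these compounds have been measured: a 12-fold higher number from compound 1 to compound 2 (1.10 log units; beyond the scatter), where bromo replaces methoxy on an aromatic carbon, and a 71-fold lower number from compound 2 to compound 3 (1.85 log units; beyond the scatter), where (dimethylamino)methyl replaces hydrogen on a saturated ring carbon. Compound 4 `CN(C)CC1CCC/C(=C\c2ccc(OC(=O)c3ccc(Cl)cc3)cc2)C1=O` keeps the (dimethylamino)methyl group of compound 3 and differs at the ester: 4-chlorophenyl in place of 2-(4-bromophenyl)ethenyl on a carbonyl carbon. Neither measured step touches the carbonyl carbon or removes the 2-(4-bromophenyl)ethenyl group, so both give only indirect guidance; the first of them does show that a change on the outer aromatic ring can shift the number a great deal. Among the measured compounds shown here, with no direct precedent, a modest step of uncertain direction is expected. Compound 4 is estimated at 2500 nM, ranging from 700 nM to 9000 nM. That estimate means a 1.4-fold higher number from compound 3 to compound 4 (0.15 log units; within the scatter) is expected.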

Compound 4, half-maximal inhibitory concentration: 5610 nM
The estimate for compound 4 lay 2.2-fold (0.35 log units) below the measured number; the range from low to high includes it.
By their numbers in this assay, from the lowest: compound 3; then compounds 4 and 1 (each within the scatter of the next); then compound 2.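

In this assay, among the compounds shown here, the first change at this carbonyl carbon gives a 3.2-fold higher number from compound 3 to compound 4 (0.50 log units; beyond the scatter) as 4-chlorophenyl replaces 2-(4-bromophenyl)ethenyl. The 2-(4-bromophenyl)ethenyl group can therefore be lost at a modest cost, a smaller shift than either a 12-fold higher number from compound 1 to compound 2 (1.10 log units; beyond the scatter) or a 71-fold lower number from compound 2 to compound 3 (1.85 log units; beyond the scatter) on this read-out. This single step changes both the halogen and the link to the aromatic ring, and nothing available explains the result.

A 4-bromophenyl group or a 2-(4-chlorophenyl)ethenyl group on this carbonyl carbon would help show how much of the step goes with the halogen and how much with the double bond. Also open, on these data alone, is how an amide in place of the ester, or a longer amine chain in place of (dimethylamino)methyl, would affect the number.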